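The compounds below may be only part of what the source reports. "The series", "measured", "known", "first", "only" and "open" are said of these compounds alone.

Working notes on the series, following the step from compound 2 to compound 3. Compound 1 is `COC1=C(C)C(=O)/C(=C(O)/C=C/c2ccc(OC)cc2)C(=O)C1(C)C` and compound 2 is `COC1=C(C)C(=O)/C(=C(O)/C=C/c2ccccc2C)C(=O)C1(C)C`. In a functional assay on HUVEC cells (Homo sapiens) (a lower number here means that less compound is needed, a higher number that more compound is needed for the effect), compound 1 gives < 4 ug/mL, which is a limit and not a number. In this assay compound 2 gives < 4 ug/mL, likewise a limit and not a number. For the measured compounds named here, compound 2 therefore has no exact position, and the series so far amounts to the limit of < 4 ug/mL in this assay, at which 2 of the 2 values shown sit. Going by the values given here, the only measured step is a step that the two limits leave unreadable from compound 1 to compound 2.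

Compound 3 is `C=Cc1ccccc1/C=C/C(O)=C1/C(=O)C(C)=C(OC)C(C)(C)C1=O`, and the change from compound 2 is vinyl in place of methyl on an aromatic carbon, ortho to a large group. Among the compounds with values here, no measured step covers this exchange, and the one measured step has no readable size. No step beyond the scatter is expected in this assay, and no direction can be given. This expectation rests on compound 2, which gives < 4 ug/mL, a limit. The estimate implies an expected step that the limit leaves unreadable from compound 2 to compound 3. In this assay the estimated value for compound 3 is 2 ug/mL, with an expected range of 0.5 ug/mL to 6 ug/mL.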

Compound 3, concentration for half-maximal effect: < 1.1 ug/mL
Compound 3 was reported as a limit; the forecaster's own chance of this, stated with the estimate: 65%; at least 1.8-fold (0.25 log units) between middle value and limit.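

In this assay compound 3 gives < 1.1 ug/mL, a limit and not a number. For the compounds shown here, compound 1 and compound 2 also stand as limits, so no step among compound 1, compound 2 and compound 3 can be read. The compounds shown leave open whether 2-vinylphenyl and 2-methylphenyl differ at all in this assay, and by how much.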